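Sulfoxide at the chain end: an expectation for compound 3

The source may hold more compounds than are shown below. What is called first, only, known or untested is meant among the compounds shown, and "the series" means these compounds.

Measured so far:
compound 1 `CCc1cc(C(C)=O)c(O)cc1OCCCC(C)(C)C#N` gives 85%
compound 2 `CCc1cc(C(C)=O)c(O)cc1OCCCCCCSC` gives 71%

In an assay on isolated protein for inhibition of leukotriene B4 receptor 1 (Homo sapiens), tested at 10 uM (a higher number here means more inhibition at the concentration tested (going by the name of the read-out), a lower number less inhibition), compound 2 stands lowest of the two numbers shown. For the measured compounds named here, its only neighbour is compound 1, whose number is higher by the step of a number 14 percentage points lower from compound 1 to compound 2 (beyond the scatter), a modest step that lies beyond the scatter. That step swapped the end of the chain on a saturated chain carbon, three bonds along the chain from an oxygen on an aromatic ring.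

Compound 3 `CCc1cc(C(C)=O)c(O)cc1OCCCCCC[S+](C)[O-]` is not yet measured. It differs from compound 2 by a group of 3 heavy atoms (1 carbon, 1 oxygen, 1 sulfur; no ring) in place of a group of 2 heavy atoms (1 carbon, 1 sulfur; no ring), on a saturated chain carbon, six bonds along the chain from an oxygen on an aromatic ring

Going by the values given here, only the step from compound 1 to compound 2 bears on this change, and it concerns a different position and a larger swap. The change here is small, an oxygen added to the sulfur at the far end of the chain. In this assay compound 3 is therefore expected to sit close to compound 2, with a step of a number 6 percentage points lower from compound 2 to compound 3 (within the scatter) that is expected to stay within the scatter. The estimated value for compound 3 is 65%, with a range from 45% to 85%.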

Compound 3, a percentage reported as inhibition, at one concentration (the size of the read-out at that concentration, not a potency): 92%
Estimate against measurement, compound 3: 27 percentage points below, and the stated range ends below it.
By their numbers in this assay, from the lowest: compound 2; then compounds 1 and 3 (each within the scatter of the next).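

In this assay, adding one oxygen to the sulfur at the far end of the chain is not a silent change, as it gives a number 21 percentage points higher from compound 2 to compound 3 (beyond the scatter). A small edit at this place, six bonds along the chain from an oxygen on an aromatic ring, therefore moves the read-out by more than the much larger swap of chain end seen earlier. The two quite different chain ends of compound 1 and compound 3 also cannot be told apart here, with a number 7 percentage points higher from compound 1 to compound 3 (within the scatter), so a chain ending in this oxygen-bearing sulfur group does as well as one ending in the 1-cyano-1-methylethyl group, and nothing measured here explains why the added oxygen has this effect.

Still open, from the compounds shown here alone, is whether a sulfone, with a second oxygen on the same sulfur, or a carboxylic acid at the chain end would give a similar reading, and whether the result holds with a shorter or longer chain. Going by these compounds, each number is also a reading at one concentration, so how compound 2 and compound 3 compare in potency remains unknown.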